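The compounds below may be only part of what the source reports. "The series", "measured", "known", "first", "only" and "open" are said of these compounds alone.

Compound 2 `COc1cc(Cl)cc(-c2nn(-c3cccc(NC(=O)Nc4ccc(Cl)c(Cl)c4)c3)cc2-c2ccncc2)c1` and compound 1 `O=C(Nc1cccc(-n2cc(-c3ccncc3)c(-c3cc(O)cc(Cl)c3)n2)c1)Nc1ccc(Cl)c(Cl)c1` share one core and differ only by the change a number 1 percentage points lower from compound 1 to compound 2 (within the scatter), a step that stays inside the usual scatter. In a functional assay on MDA-MB-468 cells (Homo sapiens) for inhibition, read by sulforhodamine B assay, with a stated time of 48 h, tested at 100 uM (a lower number here means a stronger effect, a higher number a weaker effect of the compound at the concentration tested), compound 2 gives -18%, and compound 1 gives -17%; compound 2 is the lower of the two numbers, yet the two stand within the scatter of each other, so neither can be called the stronger.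

Compound 3 `COc1cc(Cl)cc(-c2nn(-c3cccc(NC(=O)c4cccc(C(F)(F)F)c4)c3)cc2-c2ccncc2)c1` is the next compound, still unmeasured. Its change from compound 2 is 3-(trifluoromethyl)phenyl in place of (3,4-dichlorophenyl)amino on a carbonyl carbon. Going by the values given here, the one measured step touches a different part of the molecule, so no measured step bears on this change, and there is no basis for expecting a shift beyond the scatter in this assay. The expected step is a number 6 percentage points higher from compound 2 to compound 3 (within the scatter). For compound 3 the estimate in this assay is -12%, with a range from -32% to 12%.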

Compound 3, a percentage reported as activity, at one concentration (the size of the read-out at that concentration, not a potency): 28%
Compound 3: the middle estimate sits 40 percentage points below what was measured; measured number outside the range, above it.
By their numbers in this assay, from the lowest: compounds 2 and 1 (each within the scatter of the next); then compound 3.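

In this assay, the carbonyl end of the molecule proves far more sensitive than the oxygen substituent changed earlier: 3-(trifluoromethyl)phenyl in place of (3,4-dichlorophenyl)amino gives a number 46 percentage points higher from compound 2 to compound 3 (beyond the scatter), so the effect at the tested concentration is clearly weaker. This single swap alters several features together, since the amino nitrogen with its hydrogen-bond donor leaves and the two chlorines give way to a trifluoromethyl group, so the shift cannot be assigned to any one of them. Nothing available explains why the number moved.

Still open, on these data alone, is whether the amino link or the ring substituents carry the difference. A (3-(trifluoromethyl)phenyl)amino group on the same carbonyl carbon would help separate the two, as would a 3,4-dichlorophenyl group attached directly.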